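Methoxy in Place of Bromo: Compound 3 to Compound 4

This account rests on a few compounds, and the source may have more. Where it says the series, first, only, none or still open, it means among the compounds named here.

Measured so far:
compound 1, `COc1cccc(-c2csc(N)c2C(=O)c2ccccc2)c1`: 34%
compound 2, `Nc1scc(-c2cccc(F)c2)c1C(=O)c1ccc(Cl)cc1`: 90%
compound 3, `Nc1scc(-c2cccc(Br)c2)c1C(=O)c1ccc(Cl)cc1`: 69%

In a functional assay on CHO cells for agonist activity at adenosine receptor A1 (Homo sapiens), read by fluorescence and ERK phosphorylation, with stated times of 30 min and 1.5 h, tested at 10 uM (on this read-out higher numbers stand for a stronger effect at the one concentration tested and lower numbers for a weaker effect), compound 3 gives 69%, the second highest of the three numbers. Within the data shown here, compound 2 sits above it, and the one single-point step seen so far is a number 21 percentage points lower from compound 2 to compound 3 (beyond the scatter), a modest loss. Compound 1, which carries a methoxy group and no chloro, gives the lowest number, 34%.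

Compound 4, `COc1cccc(-c2csc(N)c2C(=O)c2ccc(Cl)cc2)c1`, differs from compound 3 in one place: methoxy in place of bromo on an aromatic carbon. Among the measured compounds shown here, no measured step exchanges bromo for methoxy; the halogen swap from compound 2 to compound 3 is only loosely related, and compound 1 differs from compound 4 at a second site. The expected step is therefore uncertain and modest, a number 12 percentage points lower from compound 3 to compound 4 (beyond the scatter). Compound 4 is estimated at 57%, within 35% to 80%.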

Compound 4, a percentage reported as activity, at one concentration (the size of the read-out at that concentration, not a potency): 60%
The estimate for compound 4 lay 3 percentage points below the measured number, within the range that was stated.
By their numbers in this assay, from the lowest: compound 1; then compounds 4 and 3 (each within the scatter of the next); then compound 2.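

In this assay there is a number 9 percentage points lower from compound 3 to compound 4 (within the scatter) on exchanging bromo for methoxy, so this position does not separate these two groups, while exchanging fluoro for methoxy gives a number 30 percentage points lower from compound 2 to compound 4 (beyond the scatter) as a modest loss. Among these compounds, with methoxy held in place, chloro in place of hydrogen gives a number 26 percentage points higher from compound 1 to compound 4 (beyond the scatter) as a modest gain, the first reading of that change alone. Nothing available explains these steps. Going by these compounds, whether an amine or a carboxylic acid at this position would match fluoro or stay with bromo and methoxy remains open. So does the size of the chloro step with fluoro or bromo in this position.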